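Methyl in place of hydrogen: compound 2 to compound 3

A few compounds are considered here, and "the series" means these few. Any claim that something is new, unique, unknown or untested is made for them only; others in the source may bear on it.

Compound 1, `O=S(=O)(Nc1ccc2oc(-c3ccc(NS(=O)(=O)c4cccc5nonc45)cc3)nc2c1)c1ccc(Cl)s1`, measured in an assay on cells for inhibition of HSP60/HSP10 (Homo sapiens), with a stated time of 60 min; on this read-out higher numbers stand for weaker inhibition and lower numbers for stronger inhibition: 13000 nM.
Compound 2, `Cc1ccc(S(=O)(=O)Nc2ccc3oc(-c4ccccc4)nc3c2)cc1`: on this assay, the result for compound 2 is a limit, > 100000 nM.

Compound 1 gives a measured number in this assay, whereas compound 2 does not. For compound 2 the assay reports only a limit (the limit of > 100000 nM in this assay, at which 1 of the 2 values shown sits), so where compound 2 truly stands among the numbers shown is unknown beyond the fact that it sits at the weaker end of what the assay can report. Compound 3, `CCc1ccc(S(=O)(=O)Nc2ccc3oc(-c4ccccc4)nc3c2)cc1`, has not been measured. Compound 3 differs from compound 2 by methyl in place of hydrogen on a saturated chain carbon bound to an aromatic carbon. No step between two measured compounds is available here, so there is no measured precedent for a change of this kind in this series. The expected step of a number no higher from compound 2 to compound 3 (the limit leaves the size open) is none beyond the usual scatter, with the result for compound 3 most likely again a limit rather than a number. Compound 3 is therefore estimated at 100000 nM in this assay, in a range from 40000 nM to 300000 nM.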

Compound 3, half-maximal inhibitory concentration: > 100000 nM
Compound 3 ended at the assay's limit; the forecaster's own chance of this, stated with the estimate: 70%; the middle value sits exactly at the limit.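

Compound 2 and compound 3 each give only a limit in this assay so the step from hydrogen to methyl on the saturated chain carbon bound to an aromatic carbon cannot be read: the limit of > 100000 nM in this assay, at which 2 of the 3 values shown sit.

The compounds shown leave open whether this change alters inhibition at all, and where either compound truly stands beyond its limit.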